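Chain branching in compound 3 toward compound 4

The source may hold more compounds than are shown below. What is called first, only, known or untested is meant among the compounds shown, and "the series" means these compounds.

Compound 3 `CCCCn1ccc(-c2ccc(Oc3cccnc3C)cc2)c(C#N)c1=O` gives the largest maximal response of the three measured compounds in a functional assay on CHO cells for positive allosteric modulation of metabotropic glutamate receptor 2 (Homo sapiens), read by scintillation counting and GTPgammaS binding, with a stated time of 30 min (a lower number here means a smaller maximal response, a higher number a larger maximal response), at 228%. Among the compounds with values here, compound 2 `CC(C)CCn1ccc(-c2ccc(Oc3ccccc3)cc2)c(C#N)c1=O` stands nearest with 188%, and compound 1 `COc1ccc(-c2ccn(CCC(C)C)c(=O)c2C#N)cc1` furthest with 160%; the step of a number 28 percentage points higher from compound 1 to compound 2 (beyond the scatter) is the only measured single-point change, and it concerns the group on the oxygen on the aromatic ring, not the chain. Compound 4 `Cc1ncccc1Oc1ccc(-c2ccn(CCC(C)C)c(=O)c2C#N)cc1` differs from compound 3 by methyl in place of hydrogen on a saturated chain carbon bound to two saturated chain carbons. Within the data shown here, no measured step touches this chain, so the series gives no direct guide, and the change is small. The step expected here is a number 3 percentage points lower from compound 3 to compound 4 (within the scatter), none beyond the scatter. Compound 4 is therefore estimated at 225%, with a range from 185% to 265%.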

Compound 4, largest response reached (Emax), in percent of the reference or control that the assay uses: 256%
Beside the measured number, compound 4's estimate is 31 percentage points below it, within the range that was stated.
By their numbers in this assay, from the lowest: compound 1; then compound 2; then compound 3; then compound 4.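

Within the data shown here, the butyl to isopentyl change gives the first measured step at this chain in this assay, with methyl in place of hydrogen on a saturated chain carbon bound to two saturated chain carbons giving a number 28 percentage points higher from compound 3 to compound 4 (beyond the scatter) on the shared core. With isopentyl held, 2-methylpyridin-3-yl on the oxygen gives a number 68 percentage points higher from compound 2 to compound 4 (beyond the scatter) against phenyl and a number 96 percentage points higher from compound 1 to compound 4 (beyond the scatter) against methyl, so the group on the oxygen moves the response further than the chain change does. No evidence at hand bears on the origin of either gain.

From the compounds shown here alone, whether a longer chain such as hexyl, or a chain ending in an amine, changes the response stays open. So does whether the butyl to isopentyl step holds with phenyl or methyl on the oxygen.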